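Swapping the aryl group for an anilino on the imine nitrogen

The source may report more compounds than this note shows. Statements on the series, on what has been measured and on what is new or still open speak of the compounds shown alone.

Of the compounds shown here, three sharing one core have been measured in a functional assay on MCF7 cells (Homo sapiens) for cytotoxicity, read by sulforhodamine B assay, with a stated time of 24 h; a lower number here means a stronger inhibitor, a higher number a weaker inhibitor. Compound 1 `O=C1Nc2ccc(S(=O)(=O)N3CCOCC3)cc2/C1=N/c1ccc(O)cc1` gives 52700 nM, compound 2 `O=C1Nc2ccc(S(=O)(=O)N3CCOCC3)cc2/C1=N/c1cccc(C(F)(F)F)c1` gives 41100 nM, and compound 3 `O=C1Nc2ccc(S(=O)(=O)N3CCOCC3)cc2/C1=N/c1ccc(/N=C2\C(=O)Nc3ccc(S(=O)(=O)N4CCOCC4)cc32)cc1` gives 10900 nM. Compound 2 thus stands second highest of the three numbers, close to compound 1 and well apart from compound 3. For the measured compounds named here, the only single-point step in the set, a 1.3-fold lower number from compound 1 to compound 2 (0.11 log units; within the scatter), stays inside the scatter. Compound 4 `O=C1Nc2ccc(S(=O)(=O)N3CCOCC3)cc2/C1=N/Nc1ccccc1` differs from compound 2 by anilino in place of 3-(trifluoromethyl)phenyl on a double-bonded nitrogen. Going by the values given here, no measured step introduces an anilino, so the prior step offers the only guide, and a change within the scatter is expected: a 1.0-fold lower number from compound 2 to compound 4 (0.01 log units; within the scatter). Compound 4 is therefore estimated at 40000 nM, within 15000 nM to 100000 nM.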

Compound 4, half-maximal inhibitory concentration: 30300 nM
Compound 4: the middle estimate sits 1.3-fold (0.12 log units) above what was measured, within the range that was stated.
By their numbers in this assay, from the lowest: compound 3; then compounds 4, 2 and 1 (each within the scatter of the next).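

On the double-bonded nitrogen, anilino carries a hydrogen-bond donor and acceptor that 3-(trifluoromethyl)phenyl lacks, yet in this assay the exchange gives only a small step (a 1.4-fold lower number from compound 2 to compound 4 (0.13 log units; within the scatter)). Against 4-hydroxyphenyl the step is also small (a 1.7-fold lower number from compound 1 to compound 4 (0.24 log units; within the scatter)), so compounds 1, 2 and 4, with three different groups at this position, all lie within the scatter of one another. Nothing at hand gives a cause for these numbers.

As far as these compounds go, whether an aliphatic amine or a carboxylic acid on this nitrogen would give a step beyond the scatter remains open.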